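Aryl Amide Variation in a Triazole-Linked Aminopyrazole Series

The source may report more compounds than this note shows. Statements on the series, on what has been measured and on what is new or still open speak of the compounds shown alone.

Three compounds have been measured in a functional assay on THP-1 cells (Homo sapiens) for cytotoxicity, read by MTT assay, with a stated time of 24 h; on this read-out lower numbers stand for stronger inhibition and higher numbers for weaker inhibition:

compound 1, `CCCCCCCCCCn1cc(Cn2nc(N)c3c(C(F)(F)F)cc(-c4ccccc4)nc32)nn1`, 48.7 ug/mL
compound 2, `COc1ccc(NC(=O)Cn2cc(Cn3nc(N)c4c(C(F)(F)F)cc(-c5ccccc5)nc43)nn2)cc1`, 56.7 ug/mL
compound 3, `Cc1ccc(NC(=O)Cn2cc(Cn3nc(N)c4c(C(F)(F)F)cc(-c5ccccc5)nc43)nn2)cc1`, 41.5 ug/mL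

Compound 3 shows the lowest of the three numbers, yet the steps of a 1.2-fold lower number from compound 1 to compound 3 (0.07 log units; within the scatter) and a 1.4-fold lower number from compound 2 to compound 3 (0.14 log units; within the scatter) both lie within the scatter, as does a 1.2-fold higher number from compound 1 to compound 2 (0.07 log units; within the scatter), so the three compounds are indistinguishable on this read-out. Compound 4, `Nc1nn(Cc2cn(CC(=O)Nc3cccc(F)c3)nn2)c2nc(-c3ccccc3)cc(C(F)(F)F)c12`, differs from compound 3 by 3-fluorophenyl in place of 4-methylphenyl on an amide-type nitrogen. Going by the values given here, the only comparable step, an aryl substituent exchange, is a 1.4-fold lower number from compound 2 to compound 3 (0.14 log units; within the scatter), which was within the scatter. Compound 4 is therefore expected to give a step of a 1.1-fold higher number from compound 3 to compound 4 (0.04 log units; within the scatter), with no change beyond the scatter. The estimate for compound 4 is 45 ug/mL, in the range 25 ug/mL to 80 ug/mL.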

Compound 4, half-maximal inhibitory concentration: 99.5 ug/mL
The estimate for compound 4 lay 2.2-fold (0.34 log units) below the measured number; the whole stated range lies below it.
By their numbers in this assay, from the lowest: compounds 3, 1, 2 and 4 (each within the scatter of the next, the first and the last beyond it).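

Going by these compounds alone, the exchange of 4-methylphenyl for 3-fluorophenyl on the amide-type nitrogen gives a 2.4-fold higher number from compound 3 to compound 4 (0.38 log units; beyond the scatter) and is the first aryl change here to leave the scatter in this assay. The position also separates from nonyl in a 2.0-fold higher number from compound 1 to compound 4 (0.31 log units; beyond the scatter) but not from 4-methoxyphenyl in a 1.8-fold higher number from compound 2 to compound 4 (0.24 log units; within the scatter), so its response is modest and depends on the pair compared. No supporting measurement explains this difference.

The substituent and its ring place change together, so the compounds shown do not separate their contributions. On these data alone, how an unsubstituted phenyl on this amide would read also remains open.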